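Butoxy in place of dipropylamino: expected agonist potency

The source may hold more compounds than are shown below. What is called first, only, known or untested is meant among the compounds shown, and "the series" means these compounds.

Two compounds of the series have numbers in an assay on CHO cells for agonist activity at transient receptor potential cation channel subfamily V member 1 (Homo sapiens); a higher number here means that more compound is needed for the effect, a lower number that less compound is needed. Compound 1 `O=C(NCc1ccc(C(F)(F)F)nc1N1CCCC1)Nc1cccc2c(=O)[nH]ccc12` gives 258 nM. Compound 2 `CCCN(CCC)c1nc(C(F)(F)F)ccc1CNC(=O)Nc1cccc2c(=O)[nH]ccc12` gives 2.79 nM. Among the compounds with values here, the single measured step is a 92-fold lower number from compound 1 to compound 2 (1.97 log units; beyond the scatter), so compound 2 stands at the lower of the two numbers, with compound 1 far above it.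

Compound 3 `CCCCOc1nc(C(F)(F)F)ccc1CNC(=O)Nc1cccc2c(=O)[nH]ccc12` carries the change (butoxy in place of dipropylamino on an aromatic carbon). Within the data shown here, no measured step exchanges a nitrogen-linked group for an oxygen-linked one, and none shortens a chain; the one step available sets a ring amine against an acyclic amine and does not cover this exchange directly. What that step does show is that the group at this position moves the number a great deal, so a further change there is more likely to register beyond the scatter than not. Since the acyclic amine that gave compound 2 its low number is removed, compound 3 is expected to sit above it, with an expected step of a 5.4-fold higher number from compound 2 to compound 3 (0.73 log units; beyond the scatter). The estimate for compound 3 is 15 nM, with a range from 3 nM to 80 nM.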

Compound 3, half-maximal effective concentration: 160 nM
Estimate against measurement, compound 3: 11-fold (1.03 log units) below; the whole stated range lies below it.
By their numbers in this assay, from the lowest: compound 2; then compounds 3 and 1 (each within the scatter of the next).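

In this assay, butoxy in place of dipropylamino gives a 57-fold higher number from compound 2 to compound 3 (1.76 log units; beyond the scatter), so the low number of compound 2 does not carry over to every open-chain group at this position. Butoxy and pyrrolidin-1-yl are not separated, with a 1.6-fold lower number from compound 1 to compound 3 (0.21 log units; within the scatter); compound 3 therefore goes against any reading of the first step as ring against no ring, and among these three compounds only dipropylamino gives a number far below the others. No measurement bearing on the reason for this result is available, so the step stands as an observation about these groups alone.

The three compounds leave open whether the linking nitrogen, the presence of two chains, or both together go with the low number of compound 2, since dipropylamino and butoxy differ in all of these at once. A single-chain butylamino group would separate the linking atom from the number of chains, while diethylamino or dibutylamino would show how far the low number depends on chain length.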